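Swapping the Terminal Amine Ring on the Side Chain

This account rests on a few compounds, and the source may have more. Where it says the series, first, only, none or still open, it means among the compounds named here.

Measured compounds:
Compound 1, `COc1cc2c(Oc3ccc(NC(=O)c4nn(-c5cccc(F)c5)c(=O)cc4C)cc3F)ccnc2cc1OCCCN1CCN(C)CC1`: 260 nM
Compound 2, `COc1ccc(-n2nc(C(=O)Nc3ccc(Oc4ccnc5cc(OCCCN6CCC(C)CC6)c(OC)cc45)c(F)c3)c(C)cc2=O)cc1`: 4650 nM

In a functional assay on NCI-H460 cells (Homo sapiens) for inhibition, read by MTT assay, with a stated time of 72 h (on this read-out higher numbers stand for weaker inhibition and lower numbers for stronger inhibition), compound 2 stands highest of the two numbers; its nearest neighbour is compound 1, whose number is lower by a gap beyond the scatter, but the two differ in more than one place, so only their values can be set side by side. Compound 3 (`COc1ccc(-n2nc(C(=O)Nc3ccc(Oc4ccnc5cc(OCCCN6CCN(C)CC6)c(OC)cc45)c(F)c3)c(C)cc2=O)cc1`) is not yet measured; it differs from compound 2 by 4-methylpiperazin-1-yl in place of 4-methylpiperidin-1-yl on a saturated chain carbon, three bonds along the chain from an oxygen on an aromatic ring. Among the measured compounds shown here, with no single-point step on record, a small move toward a lower number, at most just beyond the scatter, is expected: a 1.9-fold lower number from compound 2 to compound 3 (0.27 log units; within the scatter). Compound 3 is therefore estimated at 2500 nM, within 800 nM to 8000 nM.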

Compound 3, half-maximal inhibitory concentration: 3660 nM
Compound 3: middle estimate off by 1.5-fold (0.17 log units), on the low side; low and high end bracket the measured number.
By their numbers in this assay, from the lowest: compound 1; then compounds 3 and 2 (each within the scatter of the next).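

At this position, 4-methylpiperazin-1-yl in place of 4-methylpiperidin-1-yl gives a 1.3-fold lower number from compound 2 to compound 3 (0.10 log units; within the scatter) in this assay and so does not move the number beyond the scatter. The large step is instead a 14-fold higher number from compound 1 to compound 3 (1.15 log units; beyond the scatter) with 4-methoxyphenyl in place of 3-fluorophenyl on an aromatic nitrogen. No measurement on hand explains either step.

Still open, on these data alone, is whether a morpholine or a dimethylamine in place of these rings, or a longer chain, would also leave the number within the scatter. Also open, as far as these compounds go, is how 3-chlorophenyl or unsubstituted phenyl on that aromatic nitrogen would compare.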